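Ring Expansion and Loss of N-Methyl on a Quinolinone Side Chain

The source may report more compounds than this note shows. Statements on the series, on what has been measured and on what is new or still open speak of the compounds shown alone.

Measured so far in an assay on cell membranes for binding affinity to Gonadotropin-releasing hormone receptor (Rattus norvegicus), read by radioligand binding; a lower number here means a stronger inhibitor, a higher number a weaker inhibitor:
compound 1, `Cc1cc(C)cc(-c2c(O)nc3cc(Cl)c([N+](=O)[O-])cc3c2OCC[C@@H]2CCCCN2C)c1`, gives 20 nM
compound 2, `Cc1cc(C)cc(-c2c(O)nc3cc(Cl)c([N+](=O)[O-])cc3c2OCC[C@H]2CCCCN2C)c1`, gives 85 nM

Compound 1 holds the lowest number of the two in this assay. Within the data shown here, the only measured step, a 4.3-fold higher number from compound 1 to compound 2 (0.63 log units; beyond the scatter), rests solely on (the fact that compounds 1 and 2 differ only in the configuration as drawn). Compound 3, `Cc1cc(C)cc(-c2c(O)nc3cc(Cl)c([N+](=O)[O-])cc3c2OCCC2CCCCCN2)c1`, keeps the core of compound 1 but carries azepan-2-yl in place of 1-methylpiperidin-2-yl on a saturated chain carbon, two bonds along the chain from an oxygen on an aromatic ring, with no defined stereocentre. Among the measured compounds shown here, no measured step bears on this change directly; the stereochemical step shows only that the side-chain configuration matters. Compound 3 is therefore expected at 50 nM, within 12 nM to 200 nM, a step of a 2.5-fold higher number from compound 1 to compound 3 (0.40 log units; beyond the scatter) that is estimated rather than known.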

Compound 3, half-maximal inhibitory concentration: 36 nM
For compound 3 the middle estimate is 1.4-fold (0.14 log units) above the measured one; the range from low to high includes it.
By their numbers in this assay, from the lowest: compounds 1 and 3 (each within the scatter of the next); then compound 2.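

In this assay, azepan-2-yl in place of 1-methylpiperidin-2-yl at this position gives a 1.8-fold higher number from compound 1 to compound 3 (0.26 log units; within the scatter), and a 2.4-fold lower number from compound 2 to compound 3 (0.37 log units; beyond the scatter). The position therefore accepts a seven-membered ring carrying a hydrogen-bond donor, with no defined stereocentre, and compound 3 stays level with compound 1 within the scatter. Nothing given here accounts for this step.

The compounds shown leave open whether the ring size or the methyl on nitrogen matters more, which piperidin-2-yl and 1-methylazepan-2-yl would separate. From the compounds shown here alone, how the two configurations of azepan-2-yl compare also stays open.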